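Vinyl in place of iodo, near the limit

The source may hold more compounds than are shown below. What is called first, only, known or untested is meant among the compounds shown, and "the series" means these compounds.

Compound 1 `C#Cc1nc2ccccc2s1`: 19600 nM
Compound 2 `C#Cc1ncccn1`: > 40000 nM (a limit)
Compound 3 `Ic1nc2ccccc2o1`: > 40000 nM (a limit)
Compound 4 `C=Cc1nc2ccccc2o1`: not yet measured

In a functional assay on HCT-116 cells (Homo sapiens) for cytotoxicity, with a stated time of 3 days (a lower number here means a stronger inhibitor, a higher number a weaker inhibitor), compound 3 stands only at a limit, > 40000 nM. Compound 2 also gives only a limit, > 40000 nM. The series is thus marked by the limit of > 40000 nM in this assay, at which 2 of the 3 values shown sit. Only compound 1 gives a number, 19600 nM.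

Compound 4 carries one change, vinyl in place of iodo on an aromatic carbon. Going by the values given here, no measured step gauges this change, so only a small gain, if any, is expected in this assay. The expected change is an at least 1.3-fold lower number from compound 3 to compound 4 (0.12 log units; that floor lies within the scatter). Compound 4 is estimated at 30000 nM, with an expected range of 12000 nM to 60000 nM.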

Compound 4, half-maximal inhibitory concentration: > 40000 nM
Compound 4: only a limit was reported; the forecaster's own chance of this, stated with the estimate: 45%; middle value at least 1.3-fold (0.12 log units) from the limit.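

Compound 3 and compound 4 are both reported only as limits, so no step between them can be read: the limit of > 40000 nM in this assay, at which 3 of the 4 values shown sit.

From the compounds shown here alone, whether vinyl in place of iodo on an aromatic carbon changes the read-out at all remains open.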